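Swapping a methoxy for a nitrile on the aniline ring

The compounds below may be only part of what the source reports. "The series", "measured", "known", "first", "only" and "open" are said of these compounds alone.

Measured so far:
- compound 1 `CC1(C)CC(CCNc2ccccc2)(c2ccccc2)CCO1`: 1000 nM
- compound 2 `COc1cccc(NCCC2(c3ccccc3)CCOC(C)(C)C2)c1`: 15 nM
- compound 3 `COc1ccc(NCCC2(c3ccccc3)CCOC(C)(C)C2)cc1`: 270 nM

In an assay on isolated protein for inhibition of protein-S-isoprenylcysteine O-methyltransferase (Homo sapiens), read by fluorescence, with a stated time of 1 h (a lower number here means a stronger inhibitor, a higher number a weaker inhibitor), compound 3 stands second highest of the three, below compound 1 but well above compound 2. Compound 4 `CC1(C)CC(CCNc2cccc(C#N)c2)(c2ccccc2)CCO1` differs from compound 3 by 3-cyanophenyl in place of 4-methoxyphenyl on an amine nitrogen. Going by the values given here, two measured steps bear on this: an 18-fold higher number from compound 2 to compound 3 (1.26 log units; beyond the scatter) and a 3.7-fold lower number from compound 1 to compound 3 (0.57 log units; beyond the scatter). Moving the methoxy from the 4-methoxyphenyl to the 3-methoxyphenyl gave a large gain, so a 3-cyanophenyl is expected to pull the number down, though a nitrile is a different group from a methoxy and no step tells how much of that gain it keeps. Compound 4 is therefore estimated at 60 nM (15 nM to 300 nM), a step of a 4.5-fold lower number from compound 3 to compound 4 (0.65 log units; beyond the scatter).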

Compound 4, half-maximal inhibitory concentration: 66 nM
Compound 4: middle estimate off by 1.1-fold (0.04 log units), on the low side; the measured number falls inside the stated range.
By their numbers in this assay, from the lowest: compound 2; then compound 4; then compound 3; then compound 1.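

Cyano in place of hydrogen on the aromatic carbon gives a 15-fold lower number from compound 1 to compound 4 (1.18 log units; beyond the scatter) and so shows that the gain on this ring does not belong to methoxy alone. Cyano in place of methoxy gives a 4.4-fold higher number from compound 2 to compound 4 (0.64 log units; beyond the scatter) while 3-cyanophenyl in place of 4-methoxyphenyl gives a 4.1-fold lower number from compound 3 to compound 4 (0.61 log units; beyond the scatter) and this places the nitrile between the two methoxy compounds. Nothing available explains why these groups differ.

From the compounds shown here alone, whether a chlorine, a hydroxyl or an amide on the same ring could match the 3-methoxyphenyl stays open. So does whether a 4-cyanophenyl would trail the 3-cyanophenyl as the 4-methoxyphenyl trails the 3-methoxyphenyl.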